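Fluoro for hydrogen on the aryl ring: parallel steps

The compounds below may be only part of what the source reports. "The series", "measured", "known", "first", "only" and "open" are said of these compounds alone.

Compound 1 `CCO/C(O)=C1\C(COCCNC)=NC(C)=C(C(=O)OC)C1c1ccccc1Cl` gives 3.16 nM in a functional assay on aorta for antagonist activity; on this read-out higher numbers stand for weaker inhibition and lower numbers for stronger inhibition. Compound 2 `CCO/C(O)=C1\C(COCCNC)=NC(C)=C(C(=O)OC)C1c1c(F)cccc1Cl`, which differs by fluoro in place of hydrogen on an aromatic carbon, gives 12.6 nM in this assay; the step is a 4.0-fold higher number from compound 1 to compound 2 (0.60 log units; beyond the scatter). Compound 3 `CCO/C(O)=C1\C(COCCN)=NC(C)=C(C(=O)OC)C1c1ccccc1` gives 158 nM; how its core differs from the core of compound 1 is not broken down here, so only the two values stand side by side. Compound 4 `CCO/C(O)=C1\C(COCCN)=NC(C)=C(C(=O)OC)C1c1ccccc1F` is not yet measured and differs from compound 3 by fluoro in place of hydrogen on an aromatic carbon. This is the same kind of change as that from compound 1 to compound 2, but the surroundings differ: in compound 2 the entering fluoro is also meta to a chloro group, whereas in compound 4 it is ortho to a large group only. Compound 4 is expected at 70 nM, between 20 nM and 250 nM. The expected step is a 2.3-fold lower number from compound 3 to compound 4 (0.35 log units; beyond the scatter). This rests on compound 1 at 3.16 nM standing far below compound 3 at 158 nM, though those two differ in more than one place, weighed against the measured 4.0-fold higher number from compound 1 to compound 2 (0.60 log units; beyond the scatter), which runs the other way.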

Compound 4, half-maximal inhibitory concentration: 15.9 nM
Estimate against measurement, compound 4: 4.4-fold (0.64 log units) above; the measured number lies below the stated range.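

In this assay, fluoro in place of hydrogen on an aromatic carbon does not transfer between these cores with a constant effect: on the core of compound 3 the step is a 9.9-fold lower number from compound 3 to compound 4 (1.00 log units; beyond the scatter). Set beside the earlier step, the two differ in direction and size: the same change on two cores in this assay, a 4.0-fold higher number (0.60 log units; beyond the scatter) from compound 1 to compound 2 and a 9.9-fold lower number (1.00 log units; beyond the scatter) from compound 3 to compound 4, 40-fold (1.60 log units) apart, beyond the scatter of two such steps With only two pairs, and with cores that differ in more than one place, the data do not show which difference between the cores sets this gap, nor how the change would behave on any further core.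

Open, from the compounds shown here alone, is whether trifluoromethyl or methoxy at the same place would follow fluoro. Also open, going by these compounds, is whether a longer chain ending in the amine of compound 3 would keep the step seen on that core.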